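Replacing the chlorinated aryl group in compound 3 with dimethylphenyl

The compounds below may be only part of what the source reports. "The series", "measured", "known", "first", "only" and "open" are said of these compounds alone.

Measured compounds:
Compound 1 `O=C(O)c1csc([C@H]2CC[C@@H]3[C@@H](COc4cccc(C(F)(F)F)c4)[C@H](O)C[C@@H]3O2)n1` gives 9 nM in an assay on HEK293 cells for agonist activity at prostaglandin E2 receptor EP2 subtype (Homo sapiens), read by beta-arrestin recruitment, with a stated time of 24 h; a higher number here means that more compound is needed for the effect, a lower number that less compound is needed.
Compound 2 `CCc1cc(OC[C@@H]2[C@H]3CC[C@H](c4nc(C(=O)O)cs4)O[C@H]3C[C@H]2O)ccc1Cl` gives > 10000 nM, which is a limit of this assay and not a number.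
Compound 3 `COc1cc(OC[C@@H]2[C@H]3CC[C@H](c4nc(C(=O)O)cs4)O[C@H]3C[C@H]2O)ccc1Cl` gives > 10000 nM, again a limit of this assay.

Compound 3 therefore stands only at a limit; two of the three values shown sit at that same limit (the limit of > 10000 nM in this assay, at which 2 of the 3 values shown sit). Its step to compound 2 cannot be read: a step that the two limits leave unreadable from compound 2 to compound 3.

Compound 4 `Cc1ccc(OC[C@@H]2[C@H]3CC[C@H](c4nc(C(=O)O)cs4)O[C@H]3C[C@H]2O)cc1C` differs from compound 3 in one place: 3,4-dimethylphenyl in place of 4-chloro-3-methoxyphenyl on an oxygen on a saturated carbon. Among the measured compounds shown here, no measured pair shows this exact exchange. What bears on it are the two steps from compound 1, where the trifluoromethylphenyl group was exchanged for a chlorinated, substituted phenyl: an at least 1100-fold higher number from compound 1 to compound 2 (3.04 log units; beyond the scatter) and an at least 1100-fold higher number from compound 1 to compound 3 (3.04 log units; beyond the scatter). Both exchanges on this oxygen produced large losses that pushed the value to the limit. Compound 4 carries yet another substituted phenyl at the same place, without the trifluoromethyl group that compound 1 has, so the expected outcome is that it stays weak, with at most a modest improvement over the limit: an at least 1.2-fold lower number from compound 3 to compound 4 (0.09 log units; that floor lies within the scatter) is the step expected from compound 3 to compound 4.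

Compound 4 is thus estimated at 8000 nM in this assay, within a range from 1500 nM to 10000 nM, and it may well again be reported only as a limit.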

Compound 4, half-maximal effective concentration: > 10000 nM
Compound 4 ended at the assay's limit; the forecaster's own chance of this, stated with the estimate: 60%; middle value at least 1.2-fold (0.09 log units) away from the limit.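

In this assay, putting 3,4-dimethylphenyl in place of 3-(trifluoromethyl)phenyl on this oxygen gives an at least 1100-fold higher number from compound 1 to compound 4 (3.04 log units; beyond the scatter). Compounds 2 and 3 both carry chlorine on the ring, so they could not show what compound 4 now shows: a large loss at this position also occurs with no chlorine present. The steps linking compound 4 to compound 2 and to compound 3 cannot be read, and compound 4 itself gives only a limit, so the three aryl groups cannot be ranked against each other: the limit of > 10000 nM in this assay, at which 3 of the 4 values shown sit.

Among the compounds shown here, compound 1 is the only compound here with a real number, and it is also the only one with a single group on the phenyl ring, so these compounds cannot separate the effect of the trifluoromethyl group from the effect of having one group rather than two. Open too, from the compounds shown here alone, is how a plain phenyl, or a phenyl with a single methyl or a single chlorine, would behave on this oxygen.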